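From 3-Chlorophenyl to Methyl at the Assay Limit

The source may hold more compounds than are shown below. What is called first, only, known or untested is meant among the compounds shown, and "the series" means these compounds.

Two related amides have been tested so far in an ADME assay on HT-29 cells (Homo sapiens) for antiproliferative activity, read by cell counting, with a stated time of 72 h (a lower number here means a stronger inhibitor, a higher number a weaker inhibitor), as the only test available. Compound 1 (`O=C(Nc1cccc2c1C(=O)NS2(=O)=O)c1cccc(Br)c1`) gives > 100000 nM as its result, which is a limit of the assay and not a number. Compound 2 (`O=C(Nc1ccc2c(c1)C(=O)NS2(=O)=O)c1cccc(Cl)c1`) gives > 100000 nM as its result, which is again only a limit. Compound 2 therefore stands at the limit of > 100000 nM in this assay, at which 2 of the 2 values shown sit, and has no exact number.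

Compound 3 (`CC(=O)Nc1ccc2c(c1)C(=O)NS2(=O)=O`) keeps the core of compound 2 but carries methyl in place of 3-chlorophenyl on a carbonyl carbon. Among the measured compounds shown here, no measured step shows what such a swap does. In this assay no shift beyond the usual scatter is expected (the estimated step is a number no higher from compound 2 to compound 3 (the limit leaves the size open) here). Compound 3 may well return only a limit too. For compound 3 the estimated value is 100000 nM with an expected range from 40000 nM to 200000 nM once measured.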

Compound 3, half-maximal inhibitory concentration: > 100000 nM
Compound 3 gave a limit, no number; the forecaster's own chance of this, stated with the estimate: 85%; the middle value sits exactly at the limit.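

In this assay, compound 3 gives > 100000 nM, which is a limit of the assay and not a number. Among the compounds shown here, compound 2 also gives only a limit, so no step between compound 2 and compound 3 can be read. The compounds shown leave open which structural change, if any, would yield a measurable value.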